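A few compounds are considered here, and "the series" means these few. Any claim that something is new, unique, unknown or untested is made for them only; others in the source may bear on it.

Measured so far in an assay on isolated protein for inhibition of Amine oxidase [flavin-containing] B (Homo sapiens); on this read-out higher numbers stand for weaker inhibition and lower numbers for stronger inhibition:
compound 1, `O=C(/C=C/c1cccc(F)c1)c1ccc(-n2ccnc2)cc1` — > 10000 nM
compound 2, `O=C(/C=C/c1ccc(F)cc1)c1ccc(-n2ccnc2)cc1` — > 10000 nM

Both values are limits of the assay rather than numbers. In this assay compound 1 sits at a limit, > 10000 nM. Compound 2 likewise sits at a limit, > 10000 nM. Among the compounds with values here, the one measured step, a step that the two limits leave unreadable from compound 1 to compound 2, has no readable size; the only evidence is the limit of > 10000 nM in this assay, at which 2 of the 2 values shown sit. Compound 3, `Cc1ccc(/C=C/C(=O)c2ccc(-n3ccnc3)cc2)cc1`, differs from compound 2 by methyl in place of fluoro on an aromatic carbon. With nothing readable to build on, the step that the limit leaves unreadable from compound 2 to compound 3 is expected to stay unreadable, compound 3 most likely again at the limit. Compound 3 is estimated at 20000 nM, range 7000 nM to 60000 nM.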

Compound 3, half-maximal inhibitory concentration: 320 nM
Compound 3: the middle estimate sits 63-fold (1.80 log units) above what was measured; measured number outside the range, below it.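

Methyl in place of fluoro on this aromatic carbon, para to a large group, gives a readable result in this assay: an at least 31-fold lower number from compound 2 to compound 3 (1.49 log units; beyond the scatter). The 4-methylphenyl compound also stands clear of the 3-fluorophenyl one, an at least 31-fold lower number from compound 1 to compound 3 (1.49 log units; beyond the scatter). A change of one heavy atom at this place thus separates a limit from a measured number, while the step between the two fluoro compounds cannot be read.

Open, from the compounds shown here alone, is whether ethyl, methoxy or an amine on the same carbon keeps this number. Also open, going by these compounds, is whether methyl in the place of the fluoro of compound 1 does the same.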